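Replacing the 3,4-dimethylphenyl group of compound 2

The compounds below may be only part of what the source reports. "The series", "measured", "known", "first", "only" and "open" are said of these compounds alone.

Compound 1 `C[C@H](NC(=O)C(=O)NCc1ccccc1F)C(=O)N[C@@H](CC(=O)O)C(=O)COc1c(F)c(F)cc(F)c1F`: 207 nM
Compound 2 `Cc1ccc(CNC(=O)C(=O)N[C@@H](C)C(=O)N[C@@H](CC(=O)O)C(=O)COc2c(F)c(F)cc(F)c2F)cc1C`: > 10000 nM

Both compounds were tested in a functional assay on Jurkat cells (Homo sapiens); a lower number here means a stronger inhibitor, a higher number a weaker inhibitor. Compound 2 stands at > 10000 nM, which is a limit of the assay and not a number. Compound 3 `C[C@H](NC(=O)C(=O)NCc1ccc(Cl)cc1Cl)C(=O)N[C@@H](CC(=O)O)C(=O)COc1c(F)c(F)cc(F)c1F` keeps the shared core and differs from compound 2 in one group: 2,4-dichlorophenyl in place of 3,4-dimethylphenyl on a saturated chain carbon bound to an amide-type nitrogen. In words, 2,4-dichlorophenyl takes the place of 3,4-dimethylphenyl on a saturated chain carbon bound to an amide-type nitrogen.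

Among the compounds with values here, one measured step bears on this place: an at least 48-fold higher number from compound 1 to compound 2 (1.68 log units; beyond the scatter). It was large and beyond the scatter, so the group here can weigh heavily in this assay. Neither measured compound carries 2,4-dichlorophenyl, so that step gives only a rough guide. A large fall in the number is expected, towards compound 1 at 207 nM, though perhaps not all the way. The expected change is an at least 16-fold lower number from compound 2 to compound 3 (1.22 log units; beyond the scatter). For compound 3 the estimate is 600 nM, with an expected range from 120 nM to 5000 nM.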

Compound 3, half-maximal inhibitory concentration: 165 nM
Compound 3: the middle estimate sits 3.6-fold (0.56 log units) above what was measured; measured number inside the range.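

In this assay, the change from 3,4-dimethylphenyl to 2,4-dichlorophenyl on a saturated chain carbon bound to an amide-type nitrogen gives an at least 60-fold lower number from compound 2 to compound 3 (1.78 log units; beyond the scatter), so the collapse seen with the dimethyl group does not extend to every disubstituted phenyl at this place. Set against the 2-fluorophenyl group, the same 2,4-dichlorophenyl group gives a 1.3-fold lower number from compound 1 to compound 3 (0.10 log units; within the scatter), so the two halogen-bearing rings cannot be told apart in this assay, although one carries a single fluorine and the other two chlorines. Among the three compounds, the only ring with methyl groups is the one that ends at a limit, and the step out of compound 2 is therefore a minimum, not a measured size: the limit of > 10000 nM in this assay, at which 1 of the 3 values shown sits.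

Going by these compounds, what remains open is whether the methyl groups themselves or their arrangement on the ring separate compound 2 from the other two, as the dimethyl and dichloro rings differ in both respects. On these data alone, a 2,4-dimethylphenyl or a 3,4-dichlorophenyl group at this place would pull those two apart, and the true distance of compound 2 from compound 3 stays unknown.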